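Swapping the Sulfur Substituent in a Cytotoxicity Series

The compounds below may be only part of what the source reports. "The series", "measured", "known", "first", "only" and "open" are said of these compounds alone.

The shared core carries a sulfur whose substituent is varied. Compound 1 `Cn1nc(-c2nnc(S)o2)cc1-c1ccc(C(F)(F)F)cc1` has hydrogen on that sulfur; in a functional assay on MCF7 cells (Homo sapiens) for cytotoxicity, read by MTT assay, with a stated time of 24 h (a lower number here means a stronger inhibitor, a higher number a weaker inhibitor), compound 1 gives only a limit, > 100000 nM. Compound 2 `Cn1nc(-c2nnc(SCc3c(F)cccc3F)o2)cc1-c1ccc(C(F)(F)F)cc1` gives 26200 nM in this assay. Compound 3 `Cn1nc(-c2nnc(SCCOc3ccccc3F)o2)cc1-c1ccc(C(F)(F)F)cc1` gives 23100 nM in this assay, the lowest of the two numbers, though within the scatter of compound 2. The steps of an at least 3.8-fold lower number from compound 1 to compound 2 (0.58 log units; beyond the scatter) and an at least 4.3-fold lower number from compound 1 to compound 3 (0.63 log units; beyond the scatter) show that placing an arylalkyl group on the sulfur moves the number, while a 1.1-fold lower number from compound 2 to compound 3 (0.05 log units; within the scatter) shows that exchanging one such group for another does not. Compound 4 `Cn1nc(-c2nnc(SCc3cccc(Cl)c3Cl)o2)cc1-c1ccc(C(F)(F)F)cc1` is not yet measured; its difference from compound 3 is 2,3-dichlorophenyl in place of (2-fluorophenoxy)methyl on a saturated chain carbon bound to a sulfur. For the measured compounds named here, since the only measured exchange of this kind, a 1.1-fold lower number from compound 2 to compound 3 (0.05 log units; within the scatter), lay within the scatter, the author expects no step beyond the scatter for compound 4, namely a 1.1-fold higher number from compound 3 to compound 4 (0.03 log units; within the scatter). Compound 4 is therefore estimated at 25000 nM, between 10000 nM and 60000 nM.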

Compound 4, half-maximal inhibitory concentration: 32200 nM
For compound 4 the middle estimate is 1.3-fold (0.11 log units) below the measured one, and the stated range covers the measured number.
By their numbers in this assay, from the lowest: compounds 3, 2 and 4 (each within the scatter of the next). At a limit, above all of these: compound 1.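

With this assay, the exchange on the saturated chain carbon bound to a sulfur now spans three groups without a step beyond the scatter: a 1.4-fold higher number from compound 3 to compound 4 (0.14 log units; within the scatter), and a 1.2-fold higher number from compound 2 to compound 4 (0.09 log units; within the scatter), so neither the 2,3-dichlorophenyl group in place of the 2,6-difluorophenyl group nor the loss of the ether oxygen of the (2-fluorophenoxy)methyl group separates these compounds. Placing 2,3-dichlorobenzyl in place of hydrogen on the sulfur gives an at least 3.1-fold lower number from compound 1 to compound 4 (0.49 log units; beyond the scatter), the third such replacement beyond the scatter. Compound 1 gives only a limit, so this step is a bound and not a measured size: the limit of > 100000 nM in this assay, at which 1 of the 4 values shown sits.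

All three groups shown on the sulfur carry a halogenated benzene ring. From the compounds shown here alone, whether an unsubstituted benzyl group, a plain alkyl chain, an amine or a carboxylic acid there would give a similar number remains open.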